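Hydroxy in place of pyrrolidin-1-yl: compound 1 to compound 4

This account rests on a few compounds, and the source may have more. Where it says the series, first, only, none or still open, it means among the compounds named here.

Of the compounds shown here, three have been read in an in vitro assay on HEK385-7 cells for displacement of a labelled ligand from prostaglandin D2 receptor 2 (Homo sapiens); on this read-out higher numbers stand for weaker inhibition and lower numbers for stronger inhibition. Compound 1 `O=C(O)Cc1sc(C(c2ccc(F)cc2)c2ccc(F)cc2)nc1-c1ccnc(N2CCCC2)c1` gives 230 nM in this assay, the lowest of the two numbers available. Compound 3 `O=C(O)Cc1sc(C(c2ccccc2)c2ccccn2)nc1-c1ccc(Cl)cc1` gives 810 nM in this assay, a gap to compound 1 that lies beyond the usual scatter. Compound 2 `COc1ccc(OC)c(-c2nc(C(c3ccccc3)c3ccccc3)sc2CC(=O)O)c1` yields no number in this assay but only (the limit of > 105 nM in this assay, at which 1 of the 3 values shown sits), recorded as > 105 nM.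

Compound 4 `O=C(O)Cc1sc(C(c2ccc(F)cc2)c2ccc(F)cc2)nc1-c1ccnc(O)c1` differs from compound 1 in a single place: hydroxy in place of pyrrolidin-1-yl on an aromatic carbon. Among the compounds with values here, no pair of measured compounds shares this change, so its size is not known from the series; the expectation is a moderate weakening of inhibition, of a size beyond the scatter, expressed as the expected step of a 3.9-fold higher number from compound 1 to compound 4 (0.59 log units; beyond the scatter). On that basis compound 4 is estimated to give 900 nM in this assay, with an expected range from 250 nM to 3500 nM.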

Compound 4, half-maximal inhibitory concentration: 68 nM
Compound 4: the middle estimate sits 13-fold (1.12 log units) above what was measured, and the stated range ends above it.
By their numbers in this assay, from the lowest: compound 4; then compound 1; then compound 3.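

Hydroxy in place of pyrrolidin-1-yl, next to the ring nitrogen, gives a 3.4-fold lower number from compound 1 to compound 4 (0.53 log units; beyond the scatter) in this assay. Within the data shown here, the pyrrolidin-1-yl ring is therefore not required at this position for inhibition in this pair, and the change brings in a hydrogen-bond donor that the leaving group lacks; the earlier compounds offered no comparison at this place. Nothing among the data shown accounts for the direction of this step.

Still open, as far as these compounds go, is whether the lower number depends on hydroxy itself or only on the loss of pyrrolidin-1-yl, which a methoxy group, an amino group or plain hydrogen at this place would help to separate. Also open, from the compounds shown here alone, is whether the same change gives a step of similar size on compounds that differ from compound 1 elsewhere.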